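This account rests on a few compounds, and the source may have more. Where it says the series, first, only, none or still open, it means among the compounds named here.

Three measured compounds share one core and differ in the sugar attached to it. Compound 1 `O=C1/C(=C2/C(=O)N([C@@H]3O[C@H](CO)[C@@H](O)[C@H](O)[C@H]3O)c3ccccc32)Nc2ccccc21` gives 15700 nM in a functional assay on MCF7 cells (Homo sapiens) for antiproliferative activity, read by crystal violet staining, with a stated time of 96 h; on this read-out lower numbers stand for stronger inhibition and higher numbers for weaker inhibition. Compound 2 `C[C@@H]1O[C@@H](N2C(=O)/C(=C3\Nc4ccccc4C3=O)c3ccccc32)[C@H](O)[C@H](O)[C@H]1O` gives 670 nM, a much lower number, while compound 3 `C[C@@H]1O[C@H](N2C(=O)/C(=C3\Nc4ccccc4\C3=N/O)c3ccccc32)[C@H](O)[C@H](O)[C@H]1O` gives 17000 nM, which lies within the scatter of compound 1. Among these three numbers compound 1 thus stands second highest, close to compound 3 and far from compound 2. Compound 4 `O=C1/C(=C2/C(=O)N([C@@H]3O[C@H](CO)[C@@H](O)[C@H](O)[C@@H]3O)c3ccccc32)Nc2ccccc21` has not yet been measured. Compared with compound 1 the change is the two compounds have the same atoms and bonds and differ only in configuration as drawn: 1 of 6 stereo elements differ; a stereocentre at a saturated ring carbon is drawn R in compound 1 and S in compound 4. Among the measured compounds shown here, no measured pair differs in this one place alone, so the step is uncertain; compound 4 is expected to give about 12000 nM, between 3000 nM and 50000 nM, a step of a 1.3-fold lower number from compound 1 to compound 4 (0.12 log units; within the scatter) that may well stay within the scatter.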

Compound 4, half-maximal inhibitory concentration: 4220 nM
Beside the measured number, compound 4's estimate is 2.8-fold (0.45 log units) above it; the measured number falls inside the stated range.
By their numbers in this assay, from the lowest: compound 2; then compound 4; then compounds 1 and 3 (each within the scatter of the next).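

Redrawing a single stereocentre at a saturated ring carbon from R to S gives a 3.7-fold lower number from compound 1 to compound 4 (0.57 log units; beyond the scatter) in this assay. Among the compounds shown here, no earlier pair could show this, since none differed in one place alone. The change in number can be assigned to configuration at this one carbon: the fact that compounds 1 and 4 differ only in the configuration as drawn.

Going by these compounds, whether the other stereocentres of the sugar matter as much stays open. So does what an amine or a carboxylic acid in place of the hydroxyl at this carbon would do to the number.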